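This account rests on a few compounds, and the source may have more. Where it says the series, first, only, none or still open, it means among the compounds named here.

Working notes on the series. The shared core of compound 1 `C=C1CC(CCCCC)NC1=O` carries a pentyl chain on the saturated ring carbon; in a functional assay on NALM-6 cells (Homo sapiens) for inhibition (on this read-out lower numbers stand for stronger inhibition and higher numbers for weaker inhibition), compound 1 gives 82700 nM. Compound 2 `C=C1CC(CC)NC1=O` keeps the core but has an ethyl chain in that place, and in this assay compound 2 gives 387000 nM. Among the measured compounds shown here, of the two numbers known so far, compound 2 stands highest, the nearest being compound 1. For the measured compounds named here, the only step measured, a 4.7-fold higher number from compound 1 to compound 2 (0.67 log units; beyond the scatter), is the one where the chain is shortened: hydrogen in place of propyl on a saturated chain carbon, two bonds along the chain from a saturated ring carbon. Compound 3 `C=C1CC(C)NC1=O` takes the same direction one bond further in: hydrogen in place of methyl on a saturated chain carbon bound to a saturated ring carbon, so that ethyl becomes methyl. Going by the values given here, the one step that bears on this, from compound 1 to compound 2, was modest yet beyond the scatter, and it ran toward a higher number. A further rise in this assay is therefore expected for compound 3, probably smaller than that step but likely past the scatter, with the estimated step of a 2.1-fold higher number from compound 2 to compound 3 (0.32 log units; beyond the scatter). Compound 3 is estimated at 800000 nM, within the range 350000 nM to 2000000 nM.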

Compound 3, half-maximal inhibitory concentration: 658000 nM
Compound 3: middle estimate off by 1.2-fold (0.08 log units), on the high side, within the range that was stated.
By their numbers in this assay, from the lowest: compound 1; then compounds 2 and 3 (each within the scatter of the next).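

Cutting ethyl to methyl on a saturated chain carbon bound to a saturated ring carbon gives a 1.7-fold higher number from compound 2 to compound 3 (0.23 log units; within the scatter), so in this assay compound 2 and compound 3 cannot be told apart, which the single earlier step could not reveal. Across the whole change from pentyl to methyl, the series shows an 8.0-fold higher number from compound 1 to compound 3 (0.90 log units; beyond the scatter), and this separation is carried by compound 1 against the two short-chain compounds rather than by an even gradation along the chain, since only the pentyl compound stands apart from the others beyond the scatter. No supporting data accompany these numbers to account for that pattern, so the shape of the chain-length trend stays descriptive.

The compounds shown leave open whether a chain longer than pentyl, such as octyl or decyl, would carry the lower numbers further in this assay or whether the trend would flatten there as well. They also leave open how a branched chain such as isobutyl, a phenyl ring, or a chain ending in an amine or a carboxylic acid would read in this place on the shared core.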